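Changing two stereocentres of compound 2

This account rests on a few compounds, and the source may have more. Where it says the series, first, only, none or still open, it means among the compounds named here.

In an ADME assay (Mus musculus, strain C57BL/6) for metabolic stability, read by HPLC, with a stated time of 12 h (on this read-out higher numbers stand for a longer-lived compound and lower numbers for a shorter-lived compound), compound 2 `O=C(O)[C@H](CO)NC(=O)[C@H]1C[C@@H](O)CN1` gives > 12 h, which is a limit and not a number. Compound 1 `O=C(N[C@H](CO)C(=O)O)[C@@H]1C[C@H](O)CN1` gives > 12 h, again a limit. Compound 3 `O=C(N[C@H](CO)C(=O)O)[C@@H]1C[C@@H](O)CN1` changes only the configuration as drawn: the two compounds have the same atoms and bonds and differ only in configuration as drawn: 2 of 3 stereo elements differ; a stereocentre at a saturated chain carbon is drawn S in compound 2 and R in compound 3; a stereocentre at a saturated ring carbon is drawn R in compound 2 and S in compound 3. Within the data shown here, the one measured step that bears on this, a step that the two limits leave unreadable from compound 1 to compound 2, also changes configuration alone, so it offers no size to carry over. In this assay the expected step is a step that the limit leaves unreadable from compound 2 to compound 3, within the scatter and with no direction foreseen. For compound 3 the estimated half-life is 14 h, with an expected range of 8 h to 28 h.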

Compound 3, half-life: 0.91 h
Beside the measured number, compound 3's estimate is 15-fold (1.19 log units) above it; measured number below the stated range.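

Compound 1 and compound 2 both sit at a limit, so the step between them cannot be read, and only now does configuration prove able to decide the half-life in this assay. Inverting one stereocentre at a saturated ring carbon gives an at least 13-fold lower number from compound 1 to compound 3 (1.12 log units; beyond the scatter), and changing two stereocentres gives an at least 13-fold lower number from compound 2 to compound 3 (1.12 log units; beyond the scatter). So a large fall needs no change of group here: the fact that compounds 1 and 3 differ only in the configuration as drawn

From the compounds shown here alone, the effect of inverting the chain stereocentre alone stays open. Whether compound 3 would stay as short-lived with a methyl ester in place of its carboxylic acid is also unknown.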